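Trimethoxy to dimethoxy on the aryl: cytotoxicity at one concentration

The source may hold more compounds than are shown below. What is called first, only, known or untested is meant among the compounds shown, and "the series" means these compounds.

Compound 2 `COc1cc(-c2cc(/C=C/C(=O)c3ccc(N)cc3)[nH]n2)cc(OC)c1OC` carries methoxy groups on the six-membered aromatic ring of carbon only. In a functional assay on ACHN cells (Homo sapiens) for cytotoxicity, read by sulforhodamine B assay, with a stated time of 48 h, tested at 0.1 uM (on this read-out higher numbers stand for a weaker effect at the one concentration tested and lower numbers for a stronger effect), compound 2 gives 97%. Compound 1 `COc1ccc(-c2cc(/C=C/C(=O)c3ccc(N)cc3)[nH]n2)cc1` carries a single methoxy group there, and in this assay compound 1 gives 105%. The two numbers lie within the scatter of each other, and neither marks an appreciable effect at the concentration tested. Compound 3 `COc1ccc(-c2cc(/C=C/C(=O)c3ccc(N)cc3)[nH]n2)cc1OC` differs from compound 2 by hydrogen in place of methoxy on an aromatic carbon. Among the compounds with values here, no step between measured compounds is available. No step beyond the scatter is expected, a number 3 percentage points higher from compound 2 to compound 3 (within the scatter). Compound 3 is therefore estimated at 100%, expected between 88% and 112%.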

Compound 3, a percentage reported as activity, at one concentration (the size of the read-out at that concentration, not a potency): 93%
For compound 3 the middle estimate is 7 percentage points above the measured one; low and high end bracket the measured number.
By their numbers in this assay, from the lowest: compounds 3, 2 and 1 (each within the scatter of the next, the first and the last beyond it).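

In this assay, hydrogen in place of methoxy on the trimethoxy ring makes no readable difference: a number 4 percentage points lower from compound 2 to compound 3 (within the scatter). Methoxy in place of hydrogen on the ring of compound 1 gives the first step beyond the scatter in the series, a modest one toward a stronger effect at the one concentration tested: a number 12 percentage points lower from compound 1 to compound 3 (beyond the scatter). No supporting data offer an explanation for this step. On these data alone, whether an amine, a fluorine or a carboxylic acid at this position would shift the number remains open. So does whether the step persists at a higher concentration.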